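Removing One Methoxy Group in Two Related Series

The source may report more compounds than this note shows. Statements on the series, on what has been measured and on what is new or still open speak of the compounds shown alone.

Measured compounds:
compound 1, `COc1cc(-c2cc(/C=C/C(=O)c3ccc(N)cc3)[nH]n2)cc(OC)c1OC`, -91%
compound 2, `COc1ccc(-c2cc(/C=C/C(=O)c3ccc(N)cc3)[nH]n2)cc1OC`, -86%
compound 3, `COc1cc(C(=O)/C=C/c2cc(-c3cc(OC)c(OC)c(OC)c3)n[nH]2)cc(OC)c1OC`, -99%

These three compounds were examined in a functional assay on OVCAR-8 cells (Homo sapiens) for cytotoxicity, read by sulforhodamine B assay, with a stated time of 48 h, tested at 100 uM; a lower number here means a stronger effect, a higher number a weaker effect of the compound at the concentration tested. Compound 1 and compound 2 share a core and differ in one place: hydrogen in place of methoxy on an aromatic carbon. The step this change made is a number 5 percentage points higher from compound 1 to compound 2 (within the scatter), so the two numbers cannot be told apart. Compound 3 carries a different core, and the difference between the core of compound 3 and the core of compound 1 is not broken down here; what is known is that compound 3 gave the lowest of the three numbers, that compound 1 lies within the scatter of it, and that compound 2 lies beyond the scatter of it.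

Compound 4, `COc1ccc(-c2cc(/C=C/C(=O)c3cc(OC)c(OC)c(OC)c3)[nH]n2)cc1OC`, has not yet been measured. It stands to compound 3 as compound 2 stands to compound 1: hydrogen in place of methoxy on an aromatic carbon. The surroundings of the place are the same word for word in both cases, so this is the same change made on the other core. Since the step from compound 1 to compound 2 was within the scatter, a step of similar size, a number 5 percentage points higher from compound 3 to compound 4 (within the scatter), is expected from compound 3 to compound 4 in this assay, with the value of compound 3 as the starting point. Compound 4 is therefore estimated to give -94%, with a likely range from -100% to -82%.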

Compound 4, a percentage reported as activity, at one concentration (the size of the read-out at that concentration, not a potency): -84%
Compound 4: the middle estimate sits 10 percentage points below what was measured; low and high end bracket the measured number.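

On the core of compound 3, putting hydrogen in place of methoxy on an aromatic carbon gave, in this assay, a number 15 percentage points higher from compound 3 to compound 4 (beyond the scatter), whereas the same change on the core of compound 1 gave a number 5 percentage points higher from compound 1 to compound 2 (within the scatter). Although only the first of these steps lies beyond the scatter, the two steps themselves cannot be told apart: the same change on two cores in this assay, a number 5 percentage points higher (within the scatter) from compound 1 to compound 2 and a number 15 percentage points higher (beyond the scatter) from compound 3 to compound 4, 10 percentage points apart, within the scatter of two such steps. This gives no ground for saying that the core alters the outcome of the change, so carrying it from one core to the other agrees with the data, but it does not show that the two steps are equal, since each core offers a single pair of compounds and each number is a read-out at one concentration, not a potency.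

The compounds shown have only methoxy or hydrogen at this place, so it remains open how a hydroxyl group, a chlorine atom or a longer ethoxy chain there would behave on either core. Also open, as far as these compounds go, is whether the outcome would be similar if a methoxy group were removed from another place on these compounds, or if the change were carried to a third core.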